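Notes on fluoro in place of methoxy

The source may hold more compounds than are shown below. What is called first, only, known or untested is meant among the compounds shown, and "the series" means these compounds.

Measured in a functional assay on HepG2 cells (Homo sapiens) for inhibition, read by MTT assay, with a stated time of 48 h; on this read-out higher numbers stand for weaker inhibition and lower numbers for stronger inhibition:
- compound 1 `CCc1ccc2oc(-c3ccc(NC(=O)Nc4cccc(Cl)c4)cc3Cl)cc(=O)c2c1`: 30700 nM
- compound 2 `COc1ccc2oc(-c3ccc(NC(=O)Nc4cccc(Cl)c4)cc3Cl)cc(=O)c2c1`: 26300 nM

Of the two measured compounds, compound 2 lies within the scatter of compound 1. Compound 3 `O=C(Nc1cccc(Cl)c1)Nc1ccc(-c2cc(=O)c3cc(F)ccc3o2)c(Cl)c1` has fluoro in place of methoxy on an aromatic carbon. Going by the values given here, the only measured step bearing on this change is a 1.2-fold lower number from compound 1 to compound 2 (0.07 log units; within the scatter), and it involves a different pair of groups. On that single step, no change beyond the scatter is expected in this assay. The expected step is a 1.1-fold lower number from compound 2 to compound 3 (0.02 log units; within the scatter). Compound 3 is estimated at 25000 nM, with an expected range of 10000 nM to 60000 nM.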

Compound 3, half-maximal inhibitory concentration: 31700 nM
Estimate against measurement, compound 3: 1.3-fold (0.10 log units) below; the range from low to high includes it.
By their numbers in this assay, from the lowest: compounds 2, 1 and 3 (each within the scatter of the next).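

In this assay fluoro in place of methoxy (a 1.2-fold higher number from compound 2 to compound 3 (0.08 log units; within the scatter)) and fluoro in place of ethyl (a 1.0-fold higher number from compound 1 to compound 3 (0.01 log units; within the scatter)) both stay within the scatter. Going by these compounds alone, this position on the aromatic carbon therefore now shows no separation across three groups, including a single fluorine atom, where the earlier compounds compared only methoxy and ethyl. No supporting measurement bears on this result.

Going by these compounds, whether an amine, a carboxylic acid or a longer chain here would move the number beyond the scatter remains open.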